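Amino-acid amide in place of a bis-nitrile amide

The compounds below may be only part of what the source reports. "The series", "measured", "known", "first", "only" and "open" are said of these compounds alone.

Compound 1, `CCn1c(C(=O)NCCCN(C)C)ccc1C(CC)(CC)c1ccc(OCC(O)C(C)(C)C)c(C)c1`: in an assay on isolated protein for binding affinity to vitamin D3 receptor (Homo sapiens), with a stated time of 4 h (a higher number here means a weaker inhibitor, a lower number a stronger inhibitor), compound 1 gives 197 nM.
Compound 2, `CCn1c(C(=O)NCCN)ccc1C(CC)(CC)c1ccc(OCC(O)C(C)(C)C)c(C)c1`: in this assay compound 2 gives 194 nM.
Compound 3, `CCn1c(C(=O)N(CCC#N)CCC#N)ccc1C(CC)(CC)c1ccc(OCC(O)C(C)(C)C)c(C)c1`: in this assay compound 3 gives only a limit, > 10000 nM.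

Compound 1 and compound 2 sit together, since a 1.0-fold lower number from compound 1 to compound 2 (0.01 log units; within the scatter). Compound 3 stands apart: its result is not a number but a limit, (the limit of > 10000 nM in this assay, at which 1 of the 3 values shown sits), so among the three it is the weakest binder.

Compound 4, `CC[C@@H](C)[C@H](NC(=O)c1ccc(C(CC)(CC)c2ccc(OCC(O)C(C)(C)C)c(C)c2)n1CC)C(=O)O`, has not been measured. It differs from compound 3 in one place: a group of 9 heavy atoms (6 carbon, 1 nitrogen, 2 oxygen; no ring) in place of a group of 9 heavy atoms (6 carbon, 3 nitrogen; no ring), on a carbonyl carbon. In compound 4, as in compound 1 and compound 2, the amide nitrogen carries a hydrogen, whereas in compound 3 it does not. Within the data shown here, two measured steps bear on this change, both running toward compound 3: an at least 50-fold higher number from compound 1 to compound 3 (1.70 log units; beyond the scatter) and an at least 51-fold higher number from compound 2 to compound 3 (1.71 log units; beyond the scatter). Going the other way, from compound 3 to a secondary amide, a large step toward stronger binding is therefore expected, though the carboxylic acid of compound 4 has no measured counterpart here. Compound 4 is expected to give 400 nM, with a range from 100 nM to 3000 nM. This estimate amounts to an at least 25-fold lower number from compound 3 to compound 4 (1.39 log units; beyond the scatter).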

Compound 4, half-maximal inhibitory concentration: 389 nM
Compound 4: middle estimate off by 1.0-fold (0.01 log units), on the high side; measured number inside the range.
By their numbers in this assay, from the lowest: compounds 2, 1 and 4 (each within the scatter of the next). At a limit, above all of these: compound 3.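

A carboxylic acid is tolerated at this amide: the (1-carboxy-2-methylbutyl)amino group, which keeps the amide hydrogen, gives clear binding in this assay, with an at least 25-fold lower number from compound 3 to compound 4 (1.41 log units; beyond the scatter). The size of that step rests on a limit for compound 3, not on a number: the limit of > 10000 nM in this assay, at which 1 of the 4 values shown sits. Compared with the amides ending in an amine, the acid leaves the result within the scatter, with a 2.0-fold higher number from compound 2 to compound 4 (0.30 log units; within the scatter) and a 2.0-fold higher number from compound 1 to compound 4 (0.30 log units; within the scatter), so an amine at the end of the chain is not needed for this level of binding.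

Compound 3 differs from the others in both its missing amide hydrogen and its nitrile ends, and a plain dimethylamide would be needed to pull these apart. From the compounds shown here alone, whether the side chain of compound 4 matters stays open, and a shorter carboxymethyl group or the opposite stereocentres could test this.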